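Open dithiol chain in place of the five-membered ring

The source may hold more compounds than are shown below. What is called first, only, known or untested is meant among the compounds shown, and "the series" means these compounds.

compound 1 `O=C(CCCCC1CCSS1)Nc1cccc2ccccc12` gives 2.36%
compound 2 `O=C(CCCCC(S)CCS)Nc1ccc(F)cc1` gives 5.64%
compound 3 `O=C(CCCCC(S)CCS)Nc1ccc(Cl)cn1` gives "not active" (no number reported)

In a functional assay on NCI-H460 cells (Homo sapiens) for inhibition, read by MTT assay, with a stated time of 24 h, tested at 0.1 ug/mL (on this read-out lower numbers stand for less inhibition of growth and higher numbers for more inhibition of growth at the one concentration tested), compound 1 (2.36%) lies within the scatter of compound 2 (5.64%), and compound 3 has no number. Compound 4 `O=C(CCCCC(S)CCS)Nc1cccc2ccccc12` keeps the core of compound 1 and changes one group: a group of 5 heavy atoms (3 carbon, 2 sulfur; no ring) in place of a group of 5 heavy atoms (3 carbon, 2 sulfur; one five-membered non-aromatic ring with 2 hetero atoms), on a saturated chain carbon, four bonds along the chain from a carbonyl carbon. Among the measured compounds shown here, no measured pair isolates this change. Compound 2 (5.64%) and compound 3 ("not active" (no number reported)) carry the same 1,3-disulfanylpropyl group, and neither shows more than slight inhibition. No step beyond the scatter is therefore expected in this assay. The expected change is a number 2.6 percentage points higher from compound 1 to compound 4 (within the scatter) and stays within the scatter. For compound 4 the estimated value is 5% within an expected range from 0% to 15% in this read-out.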

Compound 4, percent growth inhibition at one concentration: "not active" (no number reported)
Nothing numeric was reported for compound 4; there is nothing to compare the estimate with.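

Among the compounds shown here, compound 4 has no number in this assay, so no step from compound 1 can be read. No evidence bears on this result. The compounds shown leave open whether 1,3-disulfanylpropyl in place of the five-membered ring changes growth inhibition.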